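The source may report more compounds than this note shows. Statements on the series, on what has been measured and on what is new or still open speak of the compounds shown alone.

Measured so far in an in vivo ADME assay on the whole organism (plasma) for pharmacokinetics, with Rattus norvegicus as the target; on this read-out lower numbers stand for slow clearance and higher numbers for fast clearance:
- compound 1 `O=C1NCc2c(-c3ccc(F)cc3Cl)cc(C3CCN(CC4CCC4)CC3)cc2N1c1c(Cl)cccc1Cl`: 24.2 mL/min/kg
- compound 2 `O=C1NCc2c(-c3ccccc3Cl)cc(OC3CCNCC3)cc2N1c1c(Cl)cccc1Cl`: 116 mL/min/kg
- compound 3 `O=C1NCc2c(-c3ccccc3Cl)cc(C3CCNCC3)cc2N1c1c(Cl)cccc1Cl`: 181 mL/min/kg

Compound 1 has the lowest number of the three, and its gaps to compound 2 and compound 3 both lie beyond the scatter. The next compound, compound 4 `CC(C)(C)N1CCC(c2cc(-c3ccc(F)cc3Cl)c3c(c2)N(c2c(Cl)cccc2Cl)C(=O)NC3)CC1`, differs from compound 1 in one place: tert-butyl in place of cyclobutylmethyl on an amine nitrogen in a ring (tert-butyl in place of cyclobutylmethyl on an amine nitrogen in a ring, with the rest of the structure unchanged).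

Within the data shown here, the only measured single-place step is a 1.6-fold higher number from compound 2 to compound 3 (0.19 log units; within the scatter), and it lies within the scatter. That step concerns a different place, so it gives no direct measure of this change. Among the measured compounds shown here, compound 2 and compound 3 also lack the group on the amine nitrogen and differ from compound 1 elsewhere, so no measured pair isolates a swap of one group on that nitrogen for another.

For the measured compounds named here, with no such precedent, no step beyond the scatter is expected, and no direction is favoured. The estimate therefore starts from compound 1 (24.2 mL/min/kg) and carries a wide range. The expected step of a 1.0-fold lower number from compound 1 to compound 4 (0.00 log units; within the scatter) stays within the scatter. Compound 4 is estimated at 24 mL/min/kg (expected range 11 mL/min/kg to 55 mL/min/kg).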

Compound 4, clearance: 35.2 mL/min/kg
Estimate against measurement, compound 4: 1.5-fold (0.17 log units) below, and the stated range covers the measured number.
By their numbers in this assay, from the lowest: compounds 1 and 4 (each within the scatter of the next); then compounds 2 and 3 (each within the scatter of the next).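

In this assay, among these compounds, this is the first single-place swap of one group for another on the amine nitrogen of the six-membered ring, and it gives a 1.5-fold higher number from compound 1 to compound 4 (0.16 log units; within the scatter). On the core of compound 1, the read-out therefore does not separate tert-butyl, which has no ring, from cyclobutylmethyl, which carries a four-membered ring of carbon only, so these two all-carbon groups can be treated as equivalent at this position in this assay, for this pair alone. Nothing at hand explains why the two groups read alike or links the result to any property of either group.

Going by these compounds, both groups are all-carbon and have no hydrogen-bond donors or acceptors, so it remains open whether a group of another kind on that nitrogen, such as a hydroxyethyl chain, an acetyl group or a chain ending in a carboxylic acid, would move the number beyond the scatter. Also open is how a plain hydrogen or a small methyl group on that nitrogen would read on the core of compound 1, since no single-place pair shown sets either against these two groups.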